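A Bromophenyl Replaces the Azetidine on the Shared Core

The source may hold more compounds than are shown below. What is called first, only, known or untested is meant among the compounds shown, and "the series" means these compounds.

In an assay for inhibition of Tryptophan 2,3-dioxygenase (Homo sapiens), with stated times of 10 min and 60 min (a lower number here means a stronger inhibitor, a higher number a weaker inhibitor), compound 2 `FC(F)(F)c1cc(NCC2CNC2)c2cn[nH]c2c1` gives only a limit, > 100000 nM, and not a number. Compound 1 `COC(=O)c1cc(NCc2ccccc2[N+](=O)[O-])c2cn[nH]c2c1` likewise shows only a limit in this assay, > 100000 nM. Going by the values given here, both measured compounds therefore sit at the limit of > 100000 nM in this assay, at which 2 of the 2 values shown sit, so no measured step is available and the shared core carries no value that separates its members. From the compounds shown here alone, compound 3 `FC(F)(F)c1cc(NCc2cccc(Br)c2)c2cn[nH]c2c1` differs from compound 2 by 3-bromophenyl in place of azetidin-3-yl on a saturated chain carbon bound to a nitrogen on an aromatic ring, a change whose effect in this assay is untested. With compound 2 at a limit and compound 1 at the same limit, no direction for the step can be read from the numbers, and the estimated step is a number no higher from compound 2 to compound 3 (the limit leaves the size open), which is expected to be no change beyond the scatter. Compound 3 is thus expected to give about 100000 nM in this assay, with a range from 20000 nM to 300000 nM, and most likely again only a limit rather than a number.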

Compound 3, half-maximal inhibitory concentration: 19100 nM
Beside the measured number, compound 3's estimate is 5.2-fold (0.72 log units) above it, and the stated range ends above it.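

In this assay, compound 3 is the only one of the compounds shown that gives a number rather than a limit, so the substituent on a saturated chain carbon bound to a nitrogen on an aromatic ring can move the read-out on this shared core. Setting 3-bromophenyl in place of azetidin-3-yl gives an at least 5.2-fold lower number from compound 2 to compound 3 (0.71 log units; beyond the scatter). That step sets only a minimum for the change and not its full size, because compound 2 stands at a limit: the limit of > 100000 nM in this assay, at which 2 of the 3 values shown sit.

The compounds shown do not separate the part played by the bromine from that of the aromatic ring itself, which a plain phenyl or a 3-chlorophenyl in the same place would address. Steps to compound 1 cannot be read, as it differs from the other two compounds in more than one place.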